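The source may hold more compounds than are shown below. What is called first, only, known or untested is meant among the compounds shown, and "the series" means these compounds.

Compound 2 `O=C1N/C(=N\Cc2ccc(Cl)cc2)S/C1=C1/CCNC(=O)c2[nH]ccc21` carries a chloro group on the benzyl part of a shared core. In a functional assay on A549 cells (Homo sapiens) for inhibition, read by MTT assay, with a stated time of 48 h (on this read-out higher numbers stand for weaker inhibition and lower numbers for stronger inhibition), compound 2 gives only a limit, > 100000 nM, and not a number. Compound 1 `O=C1N/C(=N\Cc2ccccc2)S/C1=C1/CCNC(=O)c2[nH]ccc21`, with hydrogen in that place, gives 26900 nM in this assay, and compound 3 `Cc1ccc(C/N=C2\NC(=O)/C(=C3\CCNC(=O)c4[nH]ccc43)S2)cc1`, with methyl there, gives 9080 nM. The step of an at least 3.7-fold higher number from compound 1 to compound 2 (0.57 log units; beyond the scatter) and the step of an at least 11-fold lower number from compound 2 to compound 3 (1.04 log units; beyond the scatter) together place compound 2 as the weakest of the three, while a 3.0-fold lower number from compound 1 to compound 3 (0.47 log units; beyond the scatter) shows that methyl improves on hydrogen. Compound 4 `O=C1N/C(=N\Cc2ccc(F)cc2)S/C1=C1/CCNC(=O)c2[nH]ccc21` differs from compound 2 by fluoro in place of chloro on an aromatic carbon. The two steps that leave compound 2 bear on this change: each shows that exchanging the chloro for another group lowers the number, so the exchange for fluoro is expected to lower it as well, by an amount closer to the smaller of those two steps. The expected step is an at least 2.5-fold lower number from compound 2 to compound 4 (0.39 log units; beyond the scatter). Compound 4 is therefore estimated at 40000 nM, within a range from 15000 nM to 120000 nM.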

Compound 4, half-maximal inhibitory concentration: 22400 nM
For compound 4 the middle estimate is 1.8-fold (0.25 log units) above the measured one, within the range that was stated.
By their numbers in this assay, from the lowest: compound 3; then compounds 4 and 1 (each within the scatter of the next). At a limit, above all of these: compound 2.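

In this assay, the loss of activity seen with chloro does not extend to fluoro at this place, as 4-chlorobenzyl to 4-fluorobenzyl gives an at least 4.4-fold lower number from compound 2 to compound 4 (0.64 log units; beyond the scatter). Fluoro cannot be told apart from hydrogen here, with a 1.2-fold lower number from compound 1 to compound 4 (0.08 log units; within the scatter), whereas methyl keeps a real lead over fluoro, with a 2.5-fold higher number from compound 3 to compound 4 (0.39 log units; beyond the scatter). Compound 2 remains a limit and not a number, so the first of these steps gives only a minimum size: the limit of > 100000 nM in this assay, at which 1 of the 4 values shown sits.

These compounds do not tell what separates chloro from fluoro, or why methyl gives the lowest number of the set. From the compounds shown here alone, it also remains open whether a methoxy group, an amine or a bromo group at this place would give a number lower than that of compound 3.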